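The compounds below may be only part of what the source reports. "The series", "measured", "known", "first", "only" and "open" are said of these compounds alone.

Compound 1 `C=CCc1cc(-c2ccccc2C(F)(F)F)ccc1O` was tested in a functional assay on HUVEC cells (Homo sapiens) for antiproliferative activity, read by MTT assay, with a stated time of 24 h (on this read-out higher numbers stand for weaker inhibition and lower numbers for stronger inhibition), where compound 1 gives 82000 nM. Compound 2 `C=CCc1cc(-c2cc(F)cc(F)c2)ccc1O` shares the allyl-bearing phenol core of compound 1 but carries a differently decorated second ring, and in this assay compound 2 gives 80000 nM. These two numbers lie within the usual scatter of repeated measurements of each other, so compound 1 and compound 2 cannot be told apart on the numbers shown. Compound 3 `C=CCc1ccc(OCCC)c(-c2ccc(OCCC)c(CC=C)c2)c1`, in which both phenol hydrogens are replaced by propyl ether chains, reaches only the limit of this assay: compound 3 gives > 100000 nM, which is a limit of the assay rather than a number, as described by the limit of > 100000 nM in this assay, at which 1 of the 3 values shown sits.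

Compound 4 `C=CCc1cc(-c2ccccc2)ccc1O` has not yet been measured. Compared with compound 1, it differs by hydrogen in place of trifluoromethyl on an aromatic carbon. Going by the values given here, no measured pair in this set separates the effect of this single change, so the direction is uncertain; the two numbers that do exist, for compound 1 and compound 2, are both weak, and a step of a 1.1-fold higher number from compound 1 to compound 4 (0.04 log units; within the scatter) is expected, that is, no change beyond the scatter. In this assay compound 4 is therefore estimated at 90000 nM, with a range from 40000 nM to 200000 nM.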

Compound 4, half-maximal inhibitory concentration: > 100000 nM
Compound 4 ended at the assay's limit (the forecaster's own chance of this, stated with the estimate: 35%); middle value at least 1.1-fold (0.04 log units) from the limit.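

Hydrogen in place of trifluoromethyl, on an aromatic carbon ortho to a large group, gives the first pair in this set that differs in one place only, and the step reads: an at least 1.2-fold higher number from compound 1 to compound 4 (0.08 log units; that floor lies within the scatter). In this assay compound 4 gives > 100000 nM, which is a limit of the assay and not a number, so this pair fixes only a floor for the step and not its true size. Taking trifluoromethyl away from this position gave no lower number, but whether the loss of this group truly weakens inhibition cannot be read, because the measurements stop at the assay's limit: the limit of > 100000 nM in this assay, at which 2 of the 4 values shown sit.

As far as these compounds go, it remains open whether a different group at this same position, such as a methyl, a chlorine, an amine or a carboxylic acid, would move the number clearly away from this weak range. Also open, from the compounds shown here alone, is whether the same replacement would behave alike on a core that inhibits strongly enough to keep both members of the pair clear of the limit, where the size of the step could be read as a number.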